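Sulfur-linked phenyl replacing bromophenoxy on the side chain

The source may report more compounds than this note shows. Statements on the series, on what has been measured and on what is new or still open speak of the compounds shown alone.

Working notes on the series. Three compounds have numbers in an assay for inhibition of Thromboxane-A synthase (Homo sapiens), using microsomes; a lower number here means a stronger inhibitor, a higher number a weaker inhibitor. Compound 1 `O=C(O)CC/C=C\CC1COC(c2cccnc2)OC1c1cccnc1` gives 220 nM in this assay. Going by the values given here, compound 2 `O=C(O)CC/C=C\CC1COC(c2ccsc2)OC1c1cccnc1` gives 500 nM in this assay; the one recorded step is a 2.3-fold higher number from compound 1 to compound 2 (0.36 log units; beyond the scatter). Compound 3 `CC(C)(Oc1ccccc1Br)C1OCC(C/C=C\CCC(=O)O)C(c2cccnc2)O1` gives 29 nM in this assay, the lowest of the three numbers, with compound 1 nearest and compound 2 furthest, both gaps beyond the scatter.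

Compound 4 `CC(C)(Sc1ccccc1)C1OCC(C/C=C\CCC(=O)O)C(c2cccnc2)O1` is not yet measured. The change is phenylsulfanyl in place of 2-bromophenoxy on a saturated chain carbon bound to two saturated chain carbons and a saturated ring carbon. Among the compounds with values here, no measured step touches this part of the structure: the single recorded step, a 2.3-fold higher number from compound 1 to compound 2 (0.36 log units; beyond the scatter), concerns the group on a saturated ring carbon and is modest in size, so it gives no direction for the present change. The working expectation for compound 4 is therefore a small step, most likely a slight weakening, with wide bounds. Compound 4 is estimated at 60 nM in this assay, expected range 15 nM to 250 nM. The estimate for compound 4 implies an expected step of a 2.1-fold higher number from compound 3 to compound 4 (0.32 log units; beyond the scatter).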

Compound 4, half-maximal inhibitory concentration: 40 nM
Beside the measured number, compound 4's estimate is 1.5-fold (0.18 log units) above it; low and high end bracket the measured number.
By their numbers in this assay, from the lowest: compounds 3 and 4 (each within the scatter of the next); then compound 1; then compound 2.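

In this assay the change to phenylsulfanyl in place of 2-bromophenoxy on this saturated chain carbon gives a 1.4-fold higher number from compound 3 to compound 4 (0.14 log units; within the scatter) and so sets no order between the two, which shows that this position tolerates the loss of the bromine together with sulfur in place of oxygen. Going by these compounds alone, the large group on the saturated ring carbon keeps its advantage with phenylsulfanyl in place, with a 13-fold lower number from compound 2 to compound 4 (1.10 log units; beyond the scatter) and a 5.5-fold lower number from compound 1 to compound 4 (0.74 log units; beyond the scatter) as steps far larger than the one earlier step on that carbon. Nothing measured here accounts for either result.

The bromine and the linking atom change together, so a plain phenoxy or a 2-bromophenylsulfanyl group would be needed to separate them. On these data alone, how an amine or a longer chain would fare on this carbon remains open.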